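The source may report more compounds than this note shows. Statements on the series, on what has been measured and on what is new or still open speak of the compounds shown alone.

Compound 2 `Cc1ccc(CSc2cc(Cl)c(C)cc2S(=O)(=O)/N=C(\N)n2nc(C)cc2-c2ccccc2)cc1` gives 30000 nM in an ADME assay on HaCaT cells (Homo sapiens) for cytotoxicity, read by MTT assay, with a stated time of 72 h (on this read-out lower numbers stand for stronger inhibition and higher numbers for weaker inhibition), the highest of the three numbers recorded so far. Compound 1 `Cc1cccc(CSc2cc(Cl)c(C)cc2S(=O)(=O)/N=C(\N)n2nccc2-c2ccccc2)c1` gives 10000 nM in this assay, and compound 3 `Cc1cc(S(=O)(=O)/N=C(\N)n2nccc2-c2ccccc2)c(SCc2cccc(Cl)c2)cc1Cl` gives 10000 nM; each of these stands a distance beyond the scatter below compound 2, while compound 2 differs from compound 1 in more than one place, so only the two values themselves can be compared. For the measured compounds named here, the one single-point step available, no change at the digits printed from compound 1 to compound 3 (within the scatter), exchanged one substituent on the benzyl ring for another without moving the number.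

Compound 4 `Cc1cc(-c2ccccc2)n(/C(N)=N/S(=O)(=O)c2cc(C)c(Cl)cc2SCc2ccccc2)n1` is reached from compound 2 by hydrogen in place of methyl on an aromatic carbon. Going by the values given here, the step from compound 1 to compound 3 is the only measured one that touches this ring, and it was flat; no measured step removes a methyl for hydrogen. On that basis the number for compound 4 is expected to stay close to that of compound 2, with at most a modest drift downward, a step of a 1.5-fold lower number from compound 2 to compound 4 (0.18 log units; within the scatter). Compound 4 is therefore estimated at 20000 nM, within a range of 7000 nM to 50000 nM.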

Compound 4, half-maximal inhibitory concentration: 10000 nM
Compound 4: middle estimate off by 2.0-fold (0.30 log units), on the high side; measured number inside the range.
By their numbers in this assay, from the lowest: compounds 1, 3 and 4 (each within the scatter of the next); then compound 2.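

Taking away the methyl at this place, so that 4-methylbenzyl becomes benzyl, gives in this assay a 3.0-fold lower number from compound 2 to compound 4 (0.48 log units; beyond the scatter), a modest step but the first single change shown to lie beyond the scatter. For the compounds shown here, the only earlier single change, chloro in place of methyl on an aromatic carbon, gave no change at the digits printed from compound 1 to compound 3 (within the scatter), so the benzyl ring no longer stands as a part where changes have only left the number in place. Nothing at hand explains this step.

Going by these compounds, whether an amine, a methoxy group or a carboxylic acid at this place would move the number further stays open. Also open, on these data alone, is whether the same step would appear without the other methyl that compound 2 and compound 4 share on the core.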